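The source may report more compounds than this note shows. Statements on the series, on what has been measured and on what is new or still open speak of the compounds shown alone.

Compound 1 `CCCCn1ccnc1-c1cc(OC)c(OC)c(OC)c1`: > 100000 nM (a limit)
Compound 2 `COc1cc(-c2nccn2S(=O)(=O)c2ccccc2)cc(OC)c1OC`: > 100000 nM (a limit)
Compound 3 `COc1cc(-c2nccn2-c2ccc3[nH]ccc3c2)cc(OC)c1OC`: 9100 nM

In a functional assay on HT-29 cells (Homo sapiens) for antiproliferative activity, read by MTT assay, with a stated time of 72 h (a lower number here means a stronger inhibitor, a higher number a weaker inhibitor), compound 1 stands at the limit of > 100000 nM in this assay, at which 2 of the 3 values shown sit, and this is a limit, not a number. Compound 4 `COc1cc(-c2nccn2-c2ccc(Br)cc2)cc(OC)c1OC` carries 4-bromophenyl in place of butyl on an aromatic nitrogen. Among the compounds with values here, no measured step shows what such a change does. Within the data shown here, compound 3, which also has an aromatic group on that nitrogen, gives 9100 nM, and this is the only firm number available. A gain in potency is therefore expected, though its size is uncertain, and the estimated change is an at least 5.0-fold lower number from compound 1 to compound 4 (0.69 log units; beyond the scatter). For compound 4 the expected value is 20000 nM, with an estimated range from 3000 nM to 100000 nM.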

Compound 4, half-maximal inhibitory concentration: 7700 nM
Compound 4: the middle estimate sits 2.6-fold (0.41 log units) above what was measured, within the range that was stated.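

In this assay, 4-bromophenyl in place of butyl on the aromatic nitrogen gives an at least 12-fold lower number from compound 1 to compound 4 (1.11 log units; beyond the scatter), so this change at this position moves the result off the limit. The step is a bound rather than an exact size, as compound 1 holds only a limit: the limit of > 100000 nM in this assay, at which 2 of the 4 values shown sit. Compound 4, at 7700 nM, is now a second compound with an aromatic group on that nitrogen and a firm value, alongside compound 3 at 9100 nM.

Going by these compounds, what an unsubstituted phenyl on that nitrogen would give remains open, and so does the bromine's share of the step. On these data alone, a 4-methoxyphenyl or 4-aminophenyl group there is equally open.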